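Compound 3 to compound 4: ethyl for bromo

The source may report more compounds than this note shows. Statements on the series, on what has been measured and on what is new or still open speak of the compounds shown alone.

Measured in a functional assay on A2780 cells (Homo sapiens) for antiproliferative activity, read by resazurin assay, with a stated time of 72 h; on this read-out higher numbers stand for weaker inhibition and lower numbers for stronger inhibition:
- compound 1 `CN(Cc1ccccc1Cl)C(=O)c1cc2c(Cc3ccccc3)n[nH]c2cc1O`: 1100 nM
- compound 2 `CN(Cc1cccc(Br)c1)C(=O)c1cc2c(Cc3ccccc3)n[nH]c2cc1O`: 7100 nM
- compound 3 `CN(Cc1ccc(Br)cc1)C(=O)c1cc2c(Cc3ccccc3)n[nH]c2cc1O`: 2800 nM

With 2800 nM, compound 3 holds the middle place of the three values. Its nearest neighbours on either side are equally far away: a 2.5-fold higher number from compound 1 to compound 3 (0.41 log units; beyond the scatter) and a 2.5-fold lower number from compound 2 to compound 3 (0.40 log units; beyond the scatter).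

The next compound is compound 4 `CCc1ccc(CN(C)C(=O)c2cc3c(Cc4ccccc4)n[nH]c3cc2O)cc1`, not yet measured. The change is ethyl in place of bromo on an aromatic carbon, para to a large group, or 4-bromophenyl to 4-ethylphenyl.

Among the compounds with values here, no measured step exchanges the bromo for another group at this place, so the evidence is indirect. Within the data shown here, the steps that bear on it all alter the same aryl group, and all are modest: a 6.5-fold higher number from compound 1 to compound 2 (0.81 log units; beyond the scatter), alongside the two above. The largest of these sets the outer size for what a change on this aryl group has done so far. Among the measured compounds shown here, the group count changes little, and no step in this assay beyond the scatter is expected, with no preferred direction. The expected step is a 1.1-fold higher number from compound 3 to compound 4 (0.03 log units; within the scatter). For compound 4 the estimated value is 3000 nM, with an expected range from 1200 nM to 7000 nM.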

Compound 4, half-maximal inhibitory concentration: 9400 nM
Compound 4: middle estimate off by 3.1-fold (0.50 log units), on the low side; the measured number lies above the stated range.
By their numbers in this assay, from the lowest: compound 1; then compound 3; then compounds 2 and 4 (each within the scatter of the next).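

In this assay the bromo of the 4-bromophenyl group cannot be exchanged freely: ethyl on this aromatic carbon, para to a large group, gives a 3.4-fold higher number from compound 3 to compound 4 (0.53 log units; beyond the scatter), so a change of substituent without any change of place is a step of the same modest class as the earlier changes on this aryl group. The 4-ethylphenyl and 3-bromophenyl groups cannot be told apart in this series, with a 1.3-fold higher number from compound 2 to compound 4 (0.12 log units; within the scatter), while an 8.5-fold higher number from compound 1 to compound 4 (0.93 log units; beyond the scatter) is now the widest step on this aryl group and leaves the 2-chlorophenyl group with the lowest number of the four. No measurement on hand accounts for the step from bromo to ethyl.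

Open, from the compounds shown here alone, is whether the higher number belongs to ethyl alone or to carbon groups at this place in general; methyl, a longer chain such as propyl, or a methoxy group on the same carbon would separate these readings. Also open, going by these compounds, is how much of the advantage of compound 1 lies with the chlorine and how much with its place on the ring, which a 2-bromophenyl or 4-chlorophenyl group would settle.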